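The source may hold more compounds than are shown below. What is called first, only, known or untested is meant among the compounds shown, and "the series" means these compounds.

Measured so far in a toxicity assay on RAW264.7 cells (Mus musculus) for cytotoxicity, read by MTT assay, with a stated time of 24 h; a lower number here means a stronger inhibitor, a higher number a weaker inhibitor:
compound 1, `C=C[C@@](C)(/C=C/c1ccc(OCc2cn(Cc3ccc(Cl)cc3)nn2)cc1)CCC=C(C)C` — compound 1 gives 327000 nM
compound 2, `C=C[C@@](C)(/C=C/c1ccc(OCc2cn(Cc3ccc(OC)cc3)nn2)cc1)CCC=C(C)C` — compound 2 gives 273000 nM
compound 3, `C=C[C@@](C)(/C=C/c1ccc(OC(=O)c2cc3cc(Cl)ccc3[nH]2)cc1)CCC=C(C)C` — compound 3 gives 110000 nM

From compound 1 to compound 2 the change is methoxy in place of chloro on an aromatic carbon, and it gave a 1.2-fold lower number from compound 1 to compound 2 (0.08 log units; within the scatter). The difference between the core of compound 1 and the core of compound 3 is not broken down here; their values show compound 3 with the lowest number of the three, beyond the scatter from both others.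

Compound 4, `C=C[C@@](C)(/C=C/c1ccc(OC(=O)c2cc3cc(OC)ccc3[nH]2)cc1)CCC=C(C)C`, is not yet measured. It differs from compound 3 by methoxy in place of chloro on an aromatic carbon. This is the same kind of change as that from compound 1 to compound 2, but not the same: there the place was a six-membered aromatic ring of carbon only, para to a large group; here the ring is part of a fused or bridged system of two rings, meta to a fused ring and para to a fused ring.

The expected step of a 1.0-fold lower number from compound 3 to compound 4 (0.02 log units; within the scatter) rests on a 1.2-fold lower number from compound 1 to compound 2 (0.08 log units; within the scatter), which lay within the scatter. Compound 4 is expected to give about 105000 nM in this assay, estimated between 50000 nM and 230000 nM.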

Compound 4, half-maximal inhibitory concentration: 329000 nM
Beside the measured number, compound 4's estimate is 3.1-fold (0.50 log units) below it, outside the stated range (above it).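

In this assay, methoxy in place of chloro on an aromatic carbon does not carry over unchanged from one core to the other (a 3.0-fold higher number from compound 3 to compound 4 (0.48 log units; beyond the scatter)). The two steps differ: the same change on two cores in this assay, a 1.2-fold lower number (0.08 log units; within the scatter) from compound 1 to compound 2 and a 3.0-fold higher number (0.48 log units; beyond the scatter) from compound 3 to compound 4, 3.6-fold (0.55 log units) apart, beyond the scatter of two such steps
In these two pairs, the size of the step therefore depends on the core or on the place of the change. This does not show which part of the core is responsible, and two pairs give no rule for other cores.

Still open, on these data alone, is how an amine, a hydroxyl or a longer alkoxy chain at this place on the core of compound 3 would compare with chloro and methoxy. Also open, as far as these compounds go, is whether either core would keep its step with the change made elsewhere on the ring.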